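The source may report more compounds than this note shows. Statements on the series, on what has been measured and on what is new or still open speak of the compounds shown alone.

Compound 3 `NC1=NC2(CCOCC2)N(OCCCOc2ccc(Br)cc2)C(N)=N1` gives 32.5 nM in an assay on isolated protein for inhibition of Dihydrofolate reductase (Homo sapiens), read by spectrophotometry, using NADPH, with stated times of 5 s and 6 min (on this read-out lower numbers stand for stronger inhibition and higher numbers for weaker inhibition), the lowest of the two numbers available, although compound 1 `NC1=NC2(CCOCC2)N(OCCCOc2ccc(Cl)cc2)C(N)=N1` with 33.6 nM sits within the scatter of it, the step being a 1.0-fold lower number from compound 1 to compound 3 (0.01 log units; within the scatter). Compound 2 `NC1=NC2(CCOCC2)N(OCCCOc2cccc(Cl)c2Cl)C(N)=N1` has no result in this assay, reported as "not determined" (no result reported). Compound 4 `NC1=NC2(CCOCC2)N(OCCCOc2ccccc2)C(N)=N1` differs from compound 3 by hydrogen in place of bromo on an aromatic carbon. Among the compounds with values here, the only measured step, the exchange of one halogen for another between compound 1 and compound 3, left the number unchanged, so no measured step speaks directly to removing the halogen altogether. Compound 4 is therefore expected to show a step of a 1.8-fold higher number from compound 3 to compound 4 (0.27 log units; within the scatter), a somewhat higher number, with the estimate for compound 4 being 60 nM, ranging from 25 nM to 150 nM.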

Compound 4, half-maximal inhibitory concentration: 86.1 nM
Beside the measured number, compound 4's estimate is 1.4-fold (0.16 log units) below it; measured number inside the range.
By their numbers in this assay, from the lowest: compounds 3 and 1 (each within the scatter of the next); then compound 4.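

In this assay this position, para to a large group, proves not to be indifferent to its substituent: hydrogen in place of bromo gives a modest step beyond the scatter (a 2.6-fold higher number from compound 3 to compound 4 (0.42 log units; beyond the scatter)), and hydrogen in place of chloro gives a similar one (a 2.6-fold higher number from compound 1 to compound 4 (0.41 log units; beyond the scatter)). The exchange of one halogen for the other had moved nothing, whereas among these three compounds either halogen gives a lower number than hydrogen. Nothing available explains this difference. The compounds shown leave open whether a methoxy group or an amine at this position would stand with the halogens or with hydrogen. Steps to compound 2 cannot be read.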